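Lengthening the dipropylamino chain of compound 2

A few compounds are considered here, and "the series" means these few. Any claim that something is new, unique, unknown or untested is made for them only; others in the source may bear on it.

Measured so far in a functional assay on LNCaP cells (Homo sapiens) for antiproliferative activity, read by WST assay, with a stated time of 3 days; a higher number here means a weaker inhibitor, a lower number a stronger inhibitor:
- compound 1 `COc1cc(-c2oc3ccccc3c(=O)c2OC(C)C)cc(OC)c1OC` gives 8800 nM
- compound 2 `CCCN(CCC)CCCCOc1c(-c2cc(OC)c(OC)c(OC)c2)oc2ccccc2c1=O` gives 16800 nM

With only these two numbers, compound 2 sits within the usual scatter of compound 1, so neither can be ranked above the other. Among the compounds with values here, the change to compound 3 `CCCN(CCC)CCCCCOc1c(-c2cc(OC)c(OC)c(OC)c2)oc2ccccc2c1=O` is (dipropylamino)methyl in place of dipropylamino on a saturated chain carbon, four bonds along the chain from an oxygen on an aromatic ring and no measured pair isolates a change of this kind. Within the data shown here, the only measured step that bears on it is a 1.9-fold higher number from compound 1 to compound 2 (0.28 log units; within the scatter) and it replaces a whole group on the oxygen, yet it stays within the scatter. A smaller edit to the same chain is therefore not expected to move this assay beyond the scatter, in either direction. Compound 3 is estimated at 15000 nM (range 7000 nM to 32000 nM). This estimate means an expected 1.1-fold lower number from compound 2 to compound 3 (0.05 log units; within the scatter) and nothing larger.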

Compound 3, half-maximal inhibitory concentration: 7600 nM
Estimate against measurement, compound 3: 2.0-fold (0.30 log units) above; measured number inside the range.
By their numbers in this assay, from the lowest: compounds 3, 1 and 2 (each within the scatter of the next, the first and the last beyond it).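

In this assay, within the data shown here, going from the 4-(dipropylamino)butyl chain to the 5-(dipropylamino)pentyl chain on the oxygen gives a 2.2-fold lower number from compound 2 to compound 3 (0.34 log units; beyond the scatter) and this modest step is the first to lie beyond the scatter. The read-out can therefore respond to the length of this chain, a small edit that the earlier swap of a whole group did not suggest. Against the isopropyl group, however, the longer chain shows a 1.2-fold lower number from compound 1 to compound 3 (0.06 log units; within the scatter) and so compound 3 cannot be ranked above compound 1.

No evidence here gives a reason for the shift between compound 2 and compound 3. Still open, as far as these compounds go, are whether a 6-(dipropylamino)hexyl chain would move the number further and whether a morpholine ring in place of dipropylamino would leave it unchanged.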